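A Cyclobutyl Swap Across Two Related Cores

A few compounds are considered here, and "the series" means these few. Any claim that something is new, unique, unknown or untested is made for them only; others in the source may bear on it.

Compound 1 `CN(C)c1ncnc2c1ncn2C1CC1` was tested in a functional assay on the whole organism for antagonist activity, with Rattus norvegicus as the target (on this read-out higher numbers stand for an effect only at larger amounts of compound and lower numbers for an effect already at smaller amounts), and gave 9 mg/kg. Compound 2 `CN(C)c1ncnc2c1ncn2C1CCC1` carries the change (cyclobutyl in place of cyclopropyl on an aromatic nitrogen); in this assay compound 2 gives 11 mg/kg, and the step of a 1.2-fold higher number from compound 1 to compound 2 (0.09 log units; within the scatter) is small. Compound 3 `c1nc(NC2CC2)c2ncn(C3CC3)c2n1` differs from compound 1 in its core by cyclopropylamino in place of dimethylamino on an aromatic carbon; in this assay compound 3 gives 4.5 mg/kg, with the step of a 2.0-fold lower number from compound 1 to compound 3 (0.30 log units; within the scatter). Compound 4 `c1nc(NC2CC2)c2ncn(C3CCC3)c2n1` has not yet been measured. It differs from compound 3 by cyclobutyl in place of cyclopropyl on an aromatic nitrogen, which is the same change as from compound 1 to compound 2, made at the same place. Because that earlier change gave a 1.2-fold higher number from compound 1 to compound 2 (0.09 log units; within the scatter), the expected step is a 1.2-fold higher number from compound 3 to compound 4 (0.09 log units; within the scatter). For compound 4 the estimated value in this assay is 5.5 mg/kg, likely between 3 mg/kg and 10 mg/kg.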

Compound 4, dose for half-maximal effect: 19 mg/kg
The estimate for compound 4 lay 3.5-fold (0.54 log units) below the measured number; the whole stated range lies below it.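

In this assay, cyclobutyl in place of cyclopropyl on an aromatic nitrogen gave a 4.2-fold higher number from compound 3 to compound 4 (0.63 log units; beyond the scatter), so the small step seen on the core of compound 1 did not carry over to the core of compound 3: the same change on two cores in this assay, a 1.2-fold higher number (0.09 log units; within the scatter) from compound 1 to compound 2 and a 4.2-fold higher number (0.63 log units; beyond the scatter) from compound 3 to compound 4, 3.5-fold (0.54 log units) apart, beyond the scatter of two such steps Cyclopropylamino in place of dimethylamino on an aromatic carbon gave a 1.7-fold higher number from compound 2 to compound 4 (0.24 log units; within the scatter), and this step, too, differs from its counterpart on the other core: the same change on two cores in this assay, a 2.0-fold lower number (0.30 log units; within the scatter) from compound 1 to compound 3 and a 1.7-fold higher number (0.24 log units; within the scatter) from compound 2 to compound 4, 3.5-fold (0.54 log units) apart, beyond the scatter of two such steps These four compounds show that the two changes do not act independently here, but they do not show why, nor how far this extends beyond this one set.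

The compounds shown leave open how the cyclobutyl swap behaves when the aromatic carbon carries a different amine, such as methylamino or morpholine. They also leave open what a cyclopentyl group on the aromatic nitrogen would give on either core.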